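A Side-Chain Exchange Tested Against Chk2

The source may report more compounds than this note shows. Statements on the series, on what has been measured and on what is new or still open speak of the compounds shown alone.

Of the compounds shown here, three have so far been tested in an assay on isolated protein for inhibition of serine/threonine-protein kinase Chk2 (Homo sapiens), read by HTRF, tested at 10 uM; a higher number here means more inhibition at the concentration tested (going by the name of the read-out), a lower number less inhibition. Compound 1 `Cc1cccc(N(C)c2cc(Nc3cccc(C(=O)N(CC(C)C)CC(C)C)c3)ncn2)c1` gives 0%, compound 2 `COC[C@@H]1CCCN1C(=O)[C@@H]1CCCN1c1cc(Nc2cccc(OC)c2)nc(N)n1` gives 0%, and compound 3 `CN(CCCn1ccnc1)C(=O)[C@@H]1CCCN1c1nccc(Nc2ccccc2)n1` gives 5%. Compound 3 carries the highest of the three numbers, yet its value sits within the usual scatter of both compound 1 and compound 2, so the three cannot be told apart. Compound 4 `CN(C)CC(C)(C)CNC(=O)[C@@H]1CCCN1c1nccc(Nc2ccccc2)n1` is not yet measured in this assay. It differs from compound 3 in one place: (2-((dimethylamino)methyl)-2-methylpropyl)amino in place of (3-(1H-imidazol-1-yl)propyl)(methyl)amino on a carbonyl carbon. Within the data shown here, since none of the measured compounds shows inhibition beyond the scatter, no step beyond the scatter is expected here either; the estimated step is no change at the digits printed from compound 3 to compound 4 (within the scatter). Compound 4 is therefore expected to give about 5%, within a range from -10% to 20%.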

Compound 4, a percentage reported as inhibition, at one concentration (the size of the read-out at that concentration, not a potency): 0%
For compound 4 the middle estimate is 5 percentage points above the measured one, within the range that was stated.
By their numbers in this assay, from the lowest: compounds 1, 2, 4 and 3 (each within the scatter of the next).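

Replacing (3-(1H-imidazol-1-yl)propyl)(methyl)amino with (2-((dimethylamino)methyl)-2-methylpropyl)amino on the carbonyl carbon gives a number 5 percentage points lower from compound 3 to compound 4 (within the scatter) in this assay. At this place, then, removing the five-membered aromatic ring and introducing a hydrogen-bond donor does not separate the two compounds, so this exchange gives no sign of inhibition beyond the scatter. No further measurement bears on this result.

As far as these compounds go, whether any group on this carbonyl carbon can give inhibition beyond the scatter remains open. A morpholine ring or a longer chain ending in a carboxylic acid would be one way to ask.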